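Swapping one tertiary amine for another on a purine-like core

The source may hold more compounds than are shown below. What is called first, only, known or untested is meant among the compounds shown, and "the series" means these compounds.

Measured so far:
- Compound 1 `CC(C)(C)Nc1ncnc2c1ncn2Cc1ccccc1F`: > 50 mg/kg in a functional assay on the whole organism with Rattus norvegicus as the target, in the maximal electroshock model; on this read-out lower numbers stand for an effect already at smaller amounts and higher numbers for an effect only at larger amounts of compound
- Compound 2 `CCN(CC)c1ncnc2c1ncn2Cc1ccccc1F`: 4.2 mg/kg

Compound 1 reaches only a limit of this assay, not a number, in this assay; this is the limit described as the limit of > 50 mg/kg in this assay, at which 1 of the 2 values shown sits. Going by the values given here, compound 2 gives 4.2 mg/kg and so is the only compound with a real number in this assay. Among the compounds with values here, the one measured step, an at least 11-fold lower number from compound 1 to compound 2 (1.07 log units; beyond the scatter), shows that replacing a secondary amine by a tertiary one went together with a large change.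

Compound 3 `CN(c1ncnc2c1ncn2Cc1ccccc1F)C1CC1` has not yet been tested. It differs from compound 2 in one place: cyclopropyl(methyl)amino in place of diethylamino on an aromatic carbon. Both groups are tertiary amines of the same size, so the step from compound 1 to compound 2 does not directly bear on this change; it only shows that the tertiary amine in compound 2 is compatible with activity. Within the data shown here, no measured step tells how much the shape of the amine substituent matters.

Compound 3 is therefore expected to stay close to compound 2, with an expected step of a 1.2-fold higher number from compound 2 to compound 3 (0.08 log units; within the scatter). The estimate for compound 3 in this assay is 5 mg/kg, expected within the range 1.5 mg/kg to 20 mg/kg.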

Compound 3, dose for half-maximal effect: 6.8 mg/kg
Compound 3: the middle estimate sits 1.4-fold (0.13 log units) below what was measured, and the stated range covers the measured number.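

In this assay, putting cyclopropyl(methyl)amino in place of diethylamino gives a 1.6-fold higher number from compound 2 to compound 3 (0.21 log units; within the scatter), so a three-membered carbon ring on the amine nitrogen at this aromatic carbon leaves the result within the usual scatter. Compared with the (tert-butyl)amino group, the new amine gives an at least 7.3-fold lower number from compound 1 to compound 3 (0.86 log units; beyond the scatter), which means the large gap first seen with compound 2 now appears with two different tertiary amines, and neither of them goes against it. That size is only a minimum, since compound 1 reaches a limit and not a number: the limit of > 50 mg/kg in this assay, at which 1 of the 3 values shown sits.

The compounds shown leave open whether the gap follows the loss of the amine hydrogen or the change in the carbon groups, and a secondary amine such as ethylamino on the same aromatic carbon would help to separate the two. Also open, from the compounds shown here alone, is how far this position tolerates other tertiary amines, such as the smaller dimethylamino or amines with a larger ring, like pyrrolidine or morpholine.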